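Terminal amine ring size: pyrrolidine to piperidine

The source may hold more compounds than are shown below. What is called first, only, known or untested is meant among the compounds shown, and "the series" means these compounds.

For the measured compounds named here, compound 3 `COc1cc2c(Oc3ccc(NC(=O)c4nn(-c5ccc(Cl)cc5)c(=O)cc4C)cc3F)ccnc2cc1OCCCN1CCCC1` stands second highest of the three numbers so far in a functional assay on MKN-45 cells (Homo sapiens) for inhibition, read by MTT assay, with a stated time of 72 h; a higher number here means a weaker inhibitor, a lower number a stronger inhibitor. In this assay compound 1 `COc1cc2c(Oc3ccc(NC(=O)c4nn(-c5ccccc5)c(=O)cc4C)cc3F)ccnc2cc1OCCCN1CCCCC1` gives 160 nM and compound 2 `COc1cc2c(Oc3ccc(NC(=O)c4nn(-c5cccc(F)c5)c(=O)cc4C)cc3F)ccnc2cc1OCCCN1CCCCC1` gives 130 nM, while compound 3 gives 150 nM. Going by the values given here, the only single-point step between measured compounds is a 1.2-fold lower number from compound 1 to compound 2 (0.09 log units; within the scatter), a change on the aromatic carbon that does not touch the chain amine.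

Compound 4 `COc1cc2c(Oc3ccc(NC(=O)c4nn(-c5ccc(Cl)cc5)c(=O)cc4C)cc3F)ccnc2cc1OCCCN1CCCCC1` differs from compound 3 by piperidin-1-yl in place of pyrrolidin-1-yl on a saturated chain carbon, three bonds along the chain from an oxygen on an aromatic ring. Among the compounds with values here, no measured step addresses this change directly. Compounds 1 and 2 carry the piperidin-1-yl group and compound 3 carries the pyrrolidin-1-yl group, but compound 3 also differs from both elsewhere, so only the three values themselves can be compared, and all of them sit within the scatter of one another. Within the data shown here, nothing in the numbers so far separates the two ring sizes.

The expectation for compound 4 is therefore a step of about no change at the digits printed from compound 3 to compound 4 (within the scatter), with no direction beyond the scatter. Compound 4 is estimated at 150 nM in this assay, with a range from 75 nM to 300 nM.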

Compound 4, half-maximal inhibitory concentration: 230 nM
Compound 4: middle estimate off by 1.5-fold (0.19 log units), on the low side; the range from low to high includes it.
By their numbers in this assay, from the lowest: compounds 2, 3, 1 and 4 (each within the scatter of the next).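

The exchange of 3-(pyrrolidin-1-yl)propyl for 3-(piperidin-1-yl)propyl now has a direct reading in this assay as a 1.5-fold higher number from compound 3 to compound 4 (0.19 log units; within the scatter), so with the 4-chlorophenyl group held fixed, the two ring sizes are not separated at this position. With piperidin-1-yl held fixed, the group on the aromatic nitrogen gives a 1.4-fold higher number from compound 1 to compound 4 (0.16 log units; within the scatter) for chloro in place of hydrogen and a 1.8-fold higher number from compound 2 to compound 4 (0.25 log units; within the scatter) for 4-chlorophenyl in place of 3-fluorophenyl, so neither of these changes separates the compounds either. No supporting measurement bears on these steps.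

The compounds shown carry only two saturated amine rings on the chain, so the reading for morpholin-4-yl or 4-methylpiperazin-1-yl in the same place, or for a longer chain ending in piperidin-1-yl, remains open. The pyrrolidin-1-yl group appears here only with 4-chlorophenyl, which leaves open whether the two ring sizes also stay unseparated with phenyl or 3-fluorophenyl on the aromatic nitrogen.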